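Working notes: from methyl to benzyl on the chloro compound

A few compounds are considered here, and "the series" means these few. Any claim that something is new, unique, unknown or untested is made for them only; others in the source may bear on it.

- Compound 1 `CN1C(=O)C2(C(C#N)=C(N)Oc3cc4oc(-c5ccccc5)cc(=O)c4c(O)c32)c2ccccc21`: > 50000 nM (a limit of the assay)
- Compound 2 `CN1C(=O)C2(C(C#N)=C(N)Oc3cc4oc(-c5ccccc5)cc(=O)c4c(O)c32)c2cc(Cl)ccc21`: 21400 nM

For the measured compounds named here, in a functional assay on PC-3 cells (Homo sapiens) for antiproliferative activity, read by MTT assay, with a stated time of 48 h (a higher number here means a weaker inhibitor, a lower number a stronger inhibitor), compound 2 gives 21400 nM, the only actual number so far. Compound 1 is recorded only as a limit, > 50000 nM. The next compound to consider is compound 3 `N#CC1=C(N)Oc2cc3oc(-c4ccccc4)cc(=O)c3c(O)c2C12C(=O)N(Cc1ccccc1)c1ccc(Cl)cc12`, which keeps the chloro group of compound 2 and carries phenyl in place of hydrogen on a saturated chain carbon bound to an amide-type nitrogen in a ring. In words, this is phenyl in place of hydrogen on a saturated chain carbon bound to an amide-type nitrogen in a ring, or methyl to benzyl.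

Going by the values given here, only one measured step is available: an at least 2.3-fold lower number from compound 1 to compound 2 (0.36 log units; beyond the scatter). That change is chloro in place of hydrogen on an aromatic carbon, not a change at the amide-type nitrogen, so it bears only loosely on this one and gives neither a size nor a direction for it. With compound 2 at 21400 nM as the starting point, no step beyond the scatter is expected in this assay, although the uncertainty is wide. The expected step is a 1.4-fold lower number from compound 2 to compound 3 (0.15 log units; within the scatter). For compound 3 the estimated value is 15000 nM, with an expected range of 4000 nM to 50000 nM.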

Compound 3, half-maximal inhibitory concentration: > 50000 nM
Compound 3: a limit, no number; the forecaster's own chance of this, stated with the estimate: 15%; middle value at least 3.3-fold (0.52 log units) from the limit.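

In this assay the substituent on the amide-type nitrogen proves to matter, which the earlier chloro step could not show: methyl to benzyl on the chloro compound gives an at least 2.3-fold higher number from compound 2 to compound 3 (0.36 log units; beyond the scatter). Compound 3 is recorded only as a limit of the assay, > 50000 nM. The step therefore has a direction and a lower bound on its size, but no end point, so the methyl group of compound 2 is the only substituent at this position with an actual number, and how far the loss extends cannot be read: the limit of > 50000 nM in this assay, at which 2 of the 3 values shown sit.

Methyl and benzyl alone cannot separate a contribution of the phenyl ring from that of the added bulk as a whole, so the hydrogen of an unsubstituted amide nitrogen, an ethyl group, a longer chain or a benzyl ring carrying an amine or a carboxylic acid would each be needed to tell these apart. Also open is whether the same direction holds without the chloro group, since benzyl is shown only on the chloro compound and compound 1 already stands at a limit.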